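Amino in Place of Nitro Across Two Cores

This account rests on a few compounds, and the source may have more. Where it says the series, first, only, none or still open, it means among the compounds named here.

In a functional assay on HT-1080 cells (Homo sapiens) for antiproliferative activity, read by MTT assay, with a stated time of 72 h (a lower number here means a stronger inhibitor, a higher number a weaker inhibitor), three compounds have been measured:
compound 1, `COc1ccc(-c2ssc(=O)c2-c2cc(OC)c(OC)c(OC)c2)cc1[N+](=O)[O-]`, 4220 nM
compound 2, `COc1ccc(-c2ssc(=O)c2-c2cc(OC)c(OC)c(OC)c2)cc1N`, 147 nM
compound 3, `COc1ccc(-c2c(-c3cc(OC)c(OC)c(OC)c3)ss/c2=N/O)cc1[N+](=O)[O-]`, 3030 nM

The change amino in place of nitro on an aromatic carbon produces a 29-fold lower number from compound 1 to compound 2 (1.46 log units; beyond the scatter). Compound 3 rests on a different core; how that core differs from the core of compound 1 is not broken down here, and the values of compound 1 and compound 3 lie within the scatter of each other. Compound 4, `COc1ccc(-c2c(-c3cc(OC)c(OC)c(OC)c3)ss/c2=N/O)cc1N`, carries the same change, (amino in place of nitro on an aromatic carbon), on the core of compound 3, with the place described in identical words. In this assay the step for compound 4 is expected to be a 20-fold lower number from compound 3 to compound 4 (1.31 log units; beyond the scatter), set beside a 29-fold lower number from compound 1 to compound 2 (1.46 log units; beyond the scatter), and this expectation rests on that single earlier instance of the change. Compound 4 is accordingly estimated at 150 nM, with a range from 60 nM to 400 nM.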

Compound 4, half-maximal inhibitory concentration: 2910 nM
Estimate against measurement, compound 4: 19-fold (1.29 log units) below; measured number outside the range, above it.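

In this assay, amino in place of nitro on an aromatic carbon gives a 1.0-fold lower number from compound 3 to compound 4 (0.02 log units; within the scatter), so on the core of compound 3 the change leaves the two compounds within the scatter of each other. Set beside its earlier instance, the change did not carry over from one core to the other: the same change on two cores in this assay, a 29-fold lower number (1.46 log units; beyond the scatter) from compound 1 to compound 2 and a 1.0-fold lower number (0.02 log units; within the scatter) from compound 3 to compound 4, 28-fold (1.44 log units) apart, beyond the scatter of two such steps. This shows that, in these two pairs, the outcome of the change differs with the core; it does not show which feature of the cores lies behind the difference, and two pairs give no rule for any further core.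

The compounds shown leave open whether a hydroxyl or an acetamide group in place of the nitro would also give different outcomes on the two cores.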